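The source may report more compounds than this note shows. Statements on the series, on what has been measured and on what is new or still open speak of the compounds shown alone.

Measured so far, in an assay on isolated protein for agonist activity at Bile acid receptor (Homo sapiens), read by FRET; a lower number here means a smaller maximal response, a higher number a larger maximal response: compound 1 `CC(C)c1onc(-c2c(Cl)cccc2Cl)c1COc1ccc(N(C)C(=O)c2cccc(C(=O)O)c2)c(C(F)(F)F)n1` gives 110%; compound 2 `CC(C)c1onc(-c2c(Cl)cccc2Cl)c1COc1ccc(N(C)Cc2ccc(CCC(=O)O)cc2)c(C(F)(F)F)n1` gives 96%.

Among the compounds with values here, compound 2 stands as the lower of these two numbers, and the only measured step is a number 14 percentage points lower from compound 1 to compound 2 (beyond the scatter). The unmeasured compound 3 `CC(C)c1onc(-c2c(Cl)cccc2Cl)c1COc1ccc(N(C)Cc2ccc(C(=O)NS(C)(=O)=O)cc2)c(C(F)(F)F)n1` differs from compound 2 in a single place: (methylsulfonyl)carbamoyl in place of 2-carboxyethyl on an aromatic carbon. Within the data shown here, no measured step covers this change, so the one step known gives only a sense of scale: a modest shift from one acid-bearing group to another. A change of similar modest size is expected, in either direction, so the estimated step of a number 1 percentage points lower from compound 2 to compound 3 (within the scatter) is small. Compound 3 is therefore estimated at 95%, ranging from 70% to 115%.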

Compound 3, largest response reached (reported as efficacy), in percent of the reference or control that the assay uses: 105%
The estimate for compound 3 lay 10 percentage points below the measured number; the measured number falls inside the stated range.
By their numbers in this assay, from the lowest: compounds 2, 3 and 1 (each within the scatter of the next, the first and the last beyond it).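

In this assay, replacing 2-carboxyethyl with (methylsulfonyl)carbamoyl on this aromatic carbon gives a number 9 percentage points higher from compound 2 to compound 3 (within the scatter). The carboxylic acid of 2-carboxyethyl is therefore not required here for a maximal response of this size, since a larger group with more hydrogen-bond acceptors and no carboxylic acid serves equally well. Nothing available explains why these two groups match.

Going by these compounds, it remains open whether an amine or a longer chain such as 3-carboxypropyl on this carbon would give a similar response. The same exchange on the benzoyl-type linker of compound 1 is also untested by these data.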